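Working notes on four compounds in a cytotoxicity screen

This account rests on a few compounds, and the source may have more. Where it says the series, first, only, none or still open, it means among the compounds named here.

Compound 1, `COc1ccc(-c2cc(/N=C3/NC(=O)CS3)cs2)cc1`, in a functional assay on MCF7 cells (Homo sapiens) for cytotoxicity, read by MTT assay, with a stated time of 72 h (on this read-out lower numbers stand for stronger inhibition and higher numbers for weaker inhibition), gives > 50000 nM, which is a limit of the assay and not a number.
Compound 2, `O=C1CS/C(=N\c2csc(-c3ccccc3)c2)N1`, in this assay gives > 50000 nM, again only a limit.
Compound 3, `COc1cccc(N2C(=O)CS/C2=N\c2csc(-c3ccc(Cl)cc3)c2)c1`, in this assay gives > 50000 nM, also a limit.

All three measured values sit at the limit of > 50000 nM in this assay, at which 3 of the 3 values shown sit, so no ordering among them can be read. From compound 2 to compound 1 the change is methoxy in place of hydrogen on an aromatic carbon, and the step that the two limits leave unreadable from compound 2 to compound 1 cannot be sized from two limits. The difference between the cores of compound 2 and compound 3 is not broken down here.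

Compound 4, `COc1ccc(N2C(=O)CS/C2=N\c2csc(-c3ccc(Cl)cc3)c2)cc1OC`, is not yet measured. It differs from compound 3 by methoxy in place of hydrogen on an aromatic carbon, the same kind of change as from compound 2 to compound 1, though here the place is also ortho to a methoxy group, which the earlier place is not. Since compound 3 gives only > 50000 nM, the step that the limit leaves unreadable from compound 3 to compound 4 is estimated to stay unreadable, and compound 4 is expected to give roughly 80000 nM in this assay, most likely reported as a limit as well.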

Compound 4, half-maximal inhibitory concentration: 18700 nM
Compound 4: the middle estimate sits 4.3-fold (0.63 log units) above what was measured; the measured number lies below the stated range.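

In this assay, methoxy in place of hydrogen on an aromatic carbon gives an at least 2.6-fold lower number from compound 3 to compound 4 (0.42 log units; beyond the scatter), so on this core the change goes with a lower number, beyond the scatter. The same kind of change on the other core, from compound 2 to compound 1, cannot be read since both ends are limits, so nothing here shows that the result carries from one core to the other, and the place on the core of compound 4 is also ortho to a methoxy group, which the earlier place is not. No size can be compared between the two cores because nearly all values rest on a limit: the limit of > 50000 nM in this assay, at which 3 of the 4 values shown sit.

Among these compounds, compound 4, at 18700 nM, is the only compound with a number, so no ordering rests on more than this one step. On these data alone, it stays open whether methoxy at this place would lower the number without the other methoxy group, and whether an amine or a carboxylic acid there would do the same.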